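The source may report more compounds than this note shows. Statements on the series, on what has been measured and on what is new or still open speak of the compounds shown alone.

Measured so far, each in a functional assay on the whole organism (strain Swiss albino) with Mus musculus as the target, in the maximal electroshock model, with a stated time of 0.5 h; on this read-out higher numbers stand for an effect only at larger amounts of compound and lower numbers for an effect already at smaller amounts:

Compound 1 `O=C(N/N=C\c1ccc(O)cc1)Nc1nnc(COc2ccc3ccccc3c2)o1`: 100 mg/kg
Compound 2 `CN(C)c1ccc(/C=N\NC(=O)Nc2nnc(COc3ccc4ccccc4c3)o2)cc1`: 100 mg/kg
Compound 3 `O=C(N/N=C(/c1ccccc1)c1ccc([N+](=O)[O-])cc1)Nc1nnc(COc2ccc3ccccc3c2)o1`: 100 mg/kg

Compound 2 stands level with compounds 1 and 3 in this assay; its nearest neighbour is compound 1 and its furthest is compound 3, and in both cases the difference is within the scatter. Among the compounds with values here, the one measured step that keeps the shared core fixed, no change at the digits printed from compound 1 to compound 2 (within the scatter), shows no change, with dimethylamino in place of hydroxy on an aromatic carbon.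

The next compound, compound 4 `O=C(N/N=C\c1ccc([N+](=O)[O-])cc1)Nc1nnc(COc2ccc3ccccc3c2)o1`, differs from compound 2 by nitro in place of dimethylamino on an aromatic carbon. Within the data shown here, no measured step covers this exact exchange. What bears on it is the step from compound 1 to compound 2, where swapping one substituent on that aromatic carbon for another left the value unchanged, and the fact that compound 3, which carries a nitro on a phenyl ring of its own, gives the same reading as compounds 1 and 2. Across all three measured compounds the read-out has not moved. The step of no change at the digits printed from compound 2 to compound 4 (within the scatter) is therefore expected to be none beyond the scatter. For compound 4 the estimate is 100 mg/kg, with a range from 50 mg/kg to 200 mg/kg.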

Compound 4, minimum effective dose: 300 mg/kg
For compound 4 the middle estimate is 3.0-fold (0.48 log units) below the measured one, outside the stated range (above it).
By their numbers in this assay, from the lowest: compounds 1, 2 and 3 (each within the scatter of the next); then compound 4.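

In this assay, the new result shows that the group on this aromatic carbon, para to a large group, can move the read-out: nitro in place of dimethylamino gives a 3.0-fold higher number from compound 2 to compound 4 (0.48 log units; beyond the scatter), and nitro in place of hydroxy gives a 3.0-fold higher number from compound 1 to compound 4 (0.48 log units; beyond the scatter). Both steps are modest, but they set 4-nitrophenyl apart from the other two aryl groups at this position, a difference that the earlier step, no change at the digits printed from compound 1 to compound 2 (within the scatter), gave no sign of. A nitro group alone does not go with the higher number across the series, since compound 3 also carries one and gives 100 mg/kg, whereas compound 4 gives 300 mg/kg, so the effect of nitro is tied to its setting in compound 4 only as far as these printed values show.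

Nothing available here accounts for the shift seen with nitro. Going by these compounds, it remains open whether the higher number is specific to nitro or would also appear with other groups at this position, such as a chlorine atom, a methoxy group or a carboxylic acid, and where a phenyl ring with no substituent would fall.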